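This account rests on a few compounds, and the source may have more. Where it says the series, first, only, none or still open, it means among the compounds named here.

Values in a functional assay on CHO cells for agonist activity at adenosine receptor A1 (Homo sapiens), read by fluorescence and ERK phosphorylation, with stated times of 30 min and 1.5 h, tested at 10 uM; on this read-out lower numbers stand for a weaker effect and higher numbers for a stronger effect at the one concentration tested:

- compound 1 `Nc1scc(-c2ccc(Cl)cc2)c1C(=O)c1ccccc1`: 51%
- compound 2 `Nc1scc(-c2cccc(Br)c2)c1C(=O)c1ccccc1`: 76%
- compound 3 `Nc1scc(-c2ccc(Cl)cc2)c1C(=O)c1ccc(Cl)cc1`: 50%

Compound 1 and compound 2 differ by 3-bromophenyl in place of 4-chlorophenyl on an aromatic carbon; this change made the step of a number 25 percentage points higher from compound 1 to compound 2 (beyond the scatter). Compound 3 differs from compound 1 by chloro in place of hydrogen on an aromatic carbon, which made the step of a number 1 percentage points lower from compound 1 to compound 3 (within the scatter), so compound 1 and compound 3 cannot be told apart on this read-out. Among the compounds with values here, compound 2 and compound 3 have no counted step between them; their two values show compound 2 standing well clear of compound 3.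

Compound 4 `Nc1scc(-c2cccc(Br)c2)c1C(=O)c1ccc(Cl)cc1` has not yet been measured. It differs from compound 3 by 3-bromophenyl in place of 4-chlorophenyl on an aromatic carbon. This is the same kind of change as that from compound 1 to compound 2, carried out on the other core: in compound 3 the place is next to the ring atom that bears a group of 9 heavy atoms, whereas in compound 1 it is next to the ring atom that bears a group of 8 heavy atoms; the two cores themselves differ by chloro in place of hydrogen on an aromatic carbon.

The expectation for compound 4 is a step of a number 24 percentage points higher from compound 3 to compound 4 (beyond the scatter), about the size seen before, because the single precedent a number 25 percentage points higher from compound 1 to compound 2 (beyond the scatter) was a clear gain and because the two cores sit so close together as shown by a number 1 percentage points lower from compound 1 to compound 3 (within the scatter). Within the data shown here, with only one precedent, the range is kept wide. Compound 4 is therefore estimated at 74% in this assay, expected to fall between 56% and 90%.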

Compound 4, a percentage reported as activity, at one concentration (the size of the read-out at that concentration, not a potency): 69%
The estimate for compound 4 lay 5 percentage points above the measured number, within the range that was stated.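

In this assay, the exchange of 4-chlorophenyl for 3-bromophenyl carries over to the core of compound 3, where the step is a number 19 percentage points higher from compound 3 to compound 4 (beyond the scatter), and its size agrees with the earlier step: the same change on two cores in this assay, a number 25 percentage points higher (beyond the scatter) from compound 1 to compound 2 and a number 19 percentage points higher (beyond the scatter) from compound 3 to compound 4, 6 percentage points apart, within the scatter of two such steps. Chloro in place of hydrogen on an aromatic carbon likewise leaves no readable mark on the bromo-bearing core, where the step is a number 7 percentage points lower from compound 2 to compound 4 (within the scatter), so this change also behaves alike on both cores: the same change on two cores in this assay, a number 1 percentage points lower (within the scatter) from compound 1 to compound 3 and a number 7 percentage points lower (within the scatter) from compound 2 to compound 4, 6 percentage points apart, within the scatter of two such steps. This transfer is shown only across two cores that differ by a single chloro, at one tested concentration, so it says nothing about potency or about cores that differ more widely, and since the halogen and its place change together, the pairs cannot assign the gain to either one alone.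

The compounds shown leave open whether 3-chlorophenyl or 4-bromophenyl would side with the 3-bromophenyl compounds or the 4-chlorophenyl compounds, which is the comparison that would separate the halogen from its place. Also open, on these data alone, is how the read-out would respond to a carboxylic acid or an amine on that phenyl ring, or to a longer chain on the amino group.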